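A few compounds are considered here, and "the series" means these few. Any claim that something is new, unique, unknown or untested is made for them only; others in the source may bear on it.

Working notes on the dichloroacetanilide series. Within the data shown here, in a functional assay on Bel-7402 cells (Homo sapiens) for antiproliferative activity, read by MTT assay, with a stated time of 72 h (a higher number here means a weaker inhibitor, a lower number a stronger inhibitor), compound 1 `O=C(Nc1ccccc1Br)C(Cl)Cl` gives 38200 nM, the only number so far in this set. For compound 2 `Cc1cccc(NC(=O)C(Cl)Cl)c1` the entry in this assay reads "not determined" (no result reported), and for compound 3 `O=C(Nc1ccc(F)cc1)C(Cl)Cl` the entry in this assay likewise reads "not determined" (no result reported), so compound 3 stands without a number alongside one further entry that also lacks one. Compound 4 `O=C(Nc1ccc(I)cc1)C(Cl)Cl` differs from compound 3 by iodo in place of fluoro on an aromatic carbon. Among the measured compounds shown here, no step between measured compounds is available to size this change; nothing in this assay points in either direction, so the expected shift relative to the neighbouring entries is none beyond the scatter. Compound 4 is expected to give about 30000 nM in this assay, with a range from 8000 nM to 100000 nM.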

Compound 4, half-maximal inhibitory concentration: 11900 nM
For compound 4 the middle estimate is 2.5-fold (0.40 log units) above the measured one, and the stated range covers the measured number.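

No step can be read between compound 3 and compound 4, as compound 3 has no single number to compare. The compounds shown leave open what iodo in place of fluoro does here, and no evidence bears on this result.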